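This account rests on a few compounds, and the source may have more. Where it says the series, first, only, none or still open, it means among the compounds named here.

Measured compounds:
Compound 1 `COc1ccc(COCNc2n[n+]([O-])c3ccccc3[n+]2[O-])cc1`: 52800 nM in a functional assay on PC-3 cells (Homo sapiens) for cytotoxicity, read by MTT assay, with a stated time of 72 h; on this read-out lower numbers stand for stronger inhibition and higher numbers for weaker inhibition.
Compound 2 `COc1ccc2c(c1)[n+]([O-])nc(NCOC(C)c1ccccc1)[n+]2[O-]`: > 100000 nM in this assay, a limit of the assay rather than a number.

Compound 1 thus holds the only number shown in this assay; the other value recorded is a limit (the limit of > 100000 nM in this assay, at which 1 of the 2 values shown sits). Compound 3 `[O-][n+]1nc(NCOCc2ccccc2)[n+]([O-])c2ccccc21` is the unmeasured partner of interest, differing from compound 1 by hydrogen in place of methoxy on an aromatic carbon. Among the measured compounds shown here, no step between measured compounds exists to show how such a change plays out in this assay, and compound 2 gives no guidance beyond its limit. The expectation is that compound 3 stays near compound 1 in this assay, with a 1.2-fold higher number from compound 1 to compound 3 (0.09 log units; within the scatter) as the estimated step, leaning toward a small loss that would not clearly exceed the scatter. Compound 3 is therefore expected at 65000 nM, within 25000 nM to 160000 nM, with a real chance that only a limit is reported.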

Compound 3, half-maximal inhibitory concentration: 11900 nM
The estimate for compound 3 lay 5.5-fold (0.74 log units) above the measured number; measured number outside the range, below it.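

Among the compounds shown here, the 4-methoxyphenyl to phenyl change in this assay gives a 4.4-fold lower number from compound 1 to compound 3 (0.65 log units; beyond the scatter) and is the first readable step. The methoxy on this aromatic carbon, para to a large group, is therefore not required for the cytotoxicity seen with compound 1, and compound 3 with hydrogen there gives the lower number. This position thus responds to substitution by more than the usual scatter, in the direction of a lower number when the methoxy leaves.

One pair at one position cannot show whether fluorine, an amine or a longer chain such as ethoxy at the same place would keep, extend or reverse this step. Compound 2 remains a limit of the assay, not a number, and offers no step on this change: the limit of > 100000 nM in this assay, at which 1 of the 3 values shown sits.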